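Swapping a chlorophenyl for a propyl chain

This account rests on a few compounds, and the source may have more. Where it says the series, first, only, none or still open, it means among the compounds named here.

Compound 1 `CCCCc1cnc(C(C)Cc2ccc(-c3ccccc3C(=O)O)cc2)[nH]1`: 2760 nM
Compound 2 `O=C(O)c1ccccc1-c1ccc(CCc2ncc(Cc3ccc(Cl)cc3)[nH]2)cc1`: 2290 nM

In an in vitro functional assay on cells for agonist activity at Bombesin receptor subtype-3 (Homo sapiens), read by luminescence and calcium flux (a higher number here means that more compound is needed for the effect, a lower number that less compound is needed), compound 2 gives 2290 nM. Compound 1 gives 2760 nM in this assay, and the two numbers sit within the scatter of each other, so neither can be called more or less potent than the other. Compound 3 `CCCCc1cnc(CCc2ccc(-c3ccccc3C(=O)O)cc2)[nH]1` has not yet been measured in this assay. It differs from compound 2 in one place: propyl in place of 4-chlorophenyl on a saturated chain carbon bound to an aromatic carbon. A ring with a chlorine is exchanged for a short chain, and the rest of the shared core is kept. Going by the values given here, no step between measured compounds shows what such an exchange does here. With both measured numbers close together, the step from compound 2 to compound 3 is expected to be small, most likely a modest rise in the needed concentration that stays near the scatter, a 1.4-fold higher number from compound 2 to compound 3 (0.15 log units; within the scatter). Compound 3 is therefore estimated at 3200 nM, between 1000 nM and 10000 nM.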

Compound 3, half-maximal effective concentration: 2710 nM
For compound 3 the middle estimate is 1.2-fold (0.07 log units) above the measured one; the range from low to high includes it.
By their numbers in this assay, from the lowest: compounds 2, 3 and 1 (each within the scatter of the next).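

In this assay, putting propyl in place of 4-chlorophenyl on a saturated chain carbon bound to an aromatic carbon gives a 1.2-fold higher number from compound 2 to compound 3 (0.07 log units; within the scatter), so at this position a chain without a ring and without chlorine does as well as the ring with chlorine. The methyl on the chain of compound 1 can also go: hydrogen in its place gives a 1.0-fold lower number from compound 1 to compound 3 (0.01 log units; within the scatter), and so neither exchange separates the compounds in this assay. Nothing available explains why such different groups give such similar numbers.

The compounds shown leave open whether an amine or a hydroxyl group at the end of the butyl chain would give a number in the same range. They also leave open what an ethyl group would do in place of that methyl.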